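The compounds below may be only part of what the source reports. "The series", "measured", "known", "first", "only" and "open" are said of these compounds alone.

Measured compounds:
compound 1 `Cc1ccc(-c2cn(-c3ccc(CN4CCCCC4)cc3)nn2)cc1Nc1nccc(-c2cccnc2)n1` — 740 nM
compound 2 `Cc1ccc(-c2cn(-c3ccc(CN4CCCC4)cc3)nn2)cc1Nc1nccc(-c2cccnc2)n1` — 1570 nM

In a functional assay on HL-60 cells (Homo sapiens) for inhibition, read by MTT assay, with a stated time of 72 h (on this read-out lower numbers stand for stronger inhibition and higher numbers for weaker inhibition), compound 1 gives 740 nM and compound 2 gives 1570 nM. Among the measured compounds shown here, compound 2 stands at the highest of the two numbers; the only step among the measured compounds is a 2.1-fold higher number from compound 1 to compound 2 (0.33 log units; beyond the scatter).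

Compound 3 `CCN(CC)c1ccc(-n2cc(-c3ccc(C)c(Nc4nccc(-c5cccnc5)n4)c3)nn2)cc1` has not been measured. It differs from compound 2 in one place: diethylamino in place of (pyrrolidin-1-yl)methyl on an aromatic carbon. For the measured compounds named here, the single measured step concerns a swap of one saturated ring for another on the chain carbon, whereas the change to compound 3 removes the chain carbon and the ring altogether and puts an acyclic amine directly on the aromatic carbon. That step therefore bears only loosely on this one, and no shown data address a diethylamino group at that position.

On this basis no step beyond the scatter is expected; the estimated step is a 1.0-fold lower number from compound 2 to compound 3 (0.02 log units; within the scatter). Compound 3 is expected to give about 1500 nM in this assay, within a range of 500 nM to 4500 nM.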

Compound 3, half-maximal inhibitory concentration: 13600 nM
The estimate for compound 3 lay 9.1-fold (0.96 log units) below the measured number; measured number above the stated range.
By their numbers in this assay, from the lowest: compound 1; then compound 2; then compound 3.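

In this assay, moving to diethylamino on this aromatic carbon, para to a large group, gives an 8.7-fold higher number from compound 2 to compound 3 (0.94 log units; beyond the scatter) and, against the piperidine member, an 18-fold higher number from compound 1 to compound 3 (1.26 log units; beyond the scatter); both steps exceed the change of ring on the chain carbon, a 2.1-fold higher number from compound 1 to compound 2 (0.33 log units; beyond the scatter). The position therefore responds far more to replacing the whole (pyrrolidin-1-yl)methyl group than to exchanging one saturated ring for the other while the chain carbon stays in place. Nothing among the data given accounts for this result.

The compounds shown leave open which part of the change carries the step, as compound 3 loses the chain carbon and the ring together. A (diethylamino)methyl group, or a pyrrolidin-1-yl group directly on the aromatic carbon, would separate the two.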